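The compounds below may be only part of what the source reports. "The series", "measured", "known", "first", "only" and "open" are said of these compounds alone.

Series notes. Compound 1 `CC(C(=O)NCc1ccc(C(C)(C)C)nc1N1CCCCCC1)c1ccc(NS(C)(=O)=O)c(F)c1` gives 0.9 nM in an assay on cells for antagonist activity at transient receptor potential cation channel subfamily V member 1 (Homo sapiens), read by FLIPR and calcium flux, with a stated time of 6 min; a higher number here means a weaker inhibitor, a lower number a stronger inhibitor. Compound 3 `CCCCOc1nc(C(C)(C)C)ccc1CNC(=O)C(C)c1ccc(NS(C)(=O)=O)c(F)c1` gives 0.9 nM in this assay, and compound 2 `CCOc1nc(C(C)(C)C)ccc1CNC(=O)C(C)c1ccc(NS(C)(=O)=O)c(F)c1` gives 14.8 nM in this assay. Compound 1 thus sits level with compound 3 at the digits shown, the two of them sharing the lowest number of the three; the only separated member is compound 2, reached by a 16-fold higher number from compound 1 to compound 2 (1.22 log units; beyond the scatter).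

Compound 4 `CC(C(=O)NCc1ccc(C(C)(C)C)nc1OC1CCCC1)c1ccc(NS(C)(=O)=O)c(F)c1` is the next member, not yet measured. Relative to compound 1 the change is cyclopentyloxy in place of azepan-1-yl on an aromatic carbon.

For the measured compounds named here, two measured steps bear on this change. Replacing azepan-1-yl by ethoxy gives a 16-fold higher number from compound 1 to compound 2 (1.22 log units; beyond the scatter), whereas replacing it by butoxy gives no change at the digits printed from compound 1 to compound 3 (within the scatter); the chain lengthening alone gives a 16-fold lower number from compound 2 to compound 3 (1.22 log units; beyond the scatter). So an oxygen-linked group at this carbon is tolerated well once it is large enough, and only the short ethoxy falls away. Cyclopentyloxy is oxygen-linked and, by the heavy-atom count given, close to butoxy rather than to ethoxy. The expectation for compound 4 in this assay is therefore a step of about a 1.7-fold higher number from compound 1 to compound 4 (0.22 log units; within the scatter), that is no change beyond the scatter. Compound 4 is estimated at 1.5 nM, with a range from 0.5 nM to 5 nM.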

Compound 4, inhibition constant: 1.5 nM
Compound 4: middle estimate and measured number agree at the digits printed; the range from low to high includes it.
By their numbers in this assay, from the lowest: compounds 1, 3 and 4 (each within the scatter of the next); then compound 2.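

In this assay, for the compounds shown here, the earlier compounds showed that this carbon tolerates azepan-1-yl and an open butoxy chain; cyclopentyloxy extends that tolerance to an oxygen-linked five-membered non-aromatic ring of carbon only, with a 1.7-fold higher number from compound 1 to compound 4 (0.22 log units; within the scatter) and a 1.7-fold higher number from compound 3 to compound 4 (0.22 log units; within the scatter), so neither the replacement of the ring nitrogen link by oxygen nor the closing of the chain into a ring separates these compounds. Going by these compounds alone, on the oxygen, cyclopentyl in place of ethyl recovers most of the ground that butyl recovered, with a 9.9-fold lower number from compound 2 to compound 4 (0.99 log units; beyond the scatter), which leaves the ethoxy of compound 2 as the only member of the four that stands apart. No measurement among these compounds accounts for the separation of ethoxy from the larger groups at this carbon.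

The compounds shown leave open how far the oxygen-linked group can grow before the number rises, for instance with a hexyloxy chain, a cyclohexyloxy or a benzyloxy group. They also leave open whether smaller nitrogen-linked rings such as pyrrolidin-1-yl or piperidin-1-yl hold up as azepan-1-yl does, or fall away as ethoxy does.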